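This account rests on a few compounds, and the source may have more. Where it says the series, first, only, none or still open, it means among the compounds named here.

Working notes on the series. Compound 1 `C=CCOc1c(C)c(C)c2c(c1C)CCC(C)(COc1ccc(/C=C3\SC(=O)NC3=O)cc1OCC)O2` carries an ethoxy on an aromatic carbon of the ring that bears the benzylidene unit. In a functional assay on MCF7 cells (Homo sapiens), tested at 5 uM (a higher number here means a weaker effect of the compound at the concentration tested, a lower number a stronger effect), compound 1 gives 87%, the highest of the three numbers in hand. Compound 3 `COc1cc(/C=C2\SC(=O)NC2=O)ccc1OCC1(C)CCc2c(C)c(OCC=C(C)C)c(C)c(C)c2O1` gives 78% in this assay, which lies within the scatter of compound 1. Going by the values given here, compound 2 `CC(C)=CCOc1c(C)c(C)c2c(c1C)CCC(C)(COc1ccc(/C=C3\SC(=O)NC3=O)cc1C)O2` gives 56%, the only number beyond the scatter of compound 1. Among the compounds with values here, the one measured step touches this position: a number 22 percentage points higher from compound 2 to compound 3 (beyond the scatter).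

Compound 4 `C=CCOc1c(C)c(C)c2c(c1C)CCC(C)(COc1ccc(/C=C3\SC(=O)NC3=O)cc1)O2` is the open question. Its difference from compound 1 is hydrogen in place of ethoxy on an aromatic carbon. Within the data shown here, the step from compound 2 to compound 3 is the only comparison that bears on it, as it also exchanges a small group at that aromatic carbon; in that pair the alkoxy gave the higher number. Among the measured compounds shown here, removing the ethoxy altogether has no direct precedent, so the expectation is loose. Compound 4 is expected to give 72% in this assay, within 50% to 94%. That implies an expected step of a number 15 percentage points lower from compound 1 to compound 4 (beyond the scatter), a modest fall in the number and thus somewhat stronger effect, though a change within the scatter would not surprise.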

Compound 4, a percentage reported as activity, at one concentration (the size of the read-out at that concentration, not a potency): 42%
Compound 4: the middle estimate sits 30 percentage points above what was measured; measured number outside the range, below it.
By their numbers in this assay, from the lowest: compound 4; then compound 2; then compounds 3 and 1 (each within the scatter of the next).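

Hydrogen in place of ethoxy on this aromatic carbon, ortho to a large group, gives in this assay a number 45 percentage points lower from compound 1 to compound 4 (beyond the scatter), a large fall and thus a much stronger effect at the concentration tested. The earlier step, a number 22 percentage points higher from compound 2 to compound 3 (beyond the scatter), exchanged one small group for another and was only modest; this pair shows what happens when the carbon carries no group at all, and that the position can move the number much further than that step suggested. Nothing at hand offers an explanation for the size of this fall.

Going by these compounds, it remains open whether a hydroxyl, a fluorine or an amine on this carbon would keep the lower number or return it towards that of compound 1. On these data alone, it is equally open whether hydrogen at this position would give a fall of similar size with the other ether chain carried by compound 2 and compound 3.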